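The source may report more compounds than this note shows. Statements on the series, on what has been measured and on what is new or still open speak of the compounds shown alone.

Three close relatives of one amide share a common core and differ only in the ring attached to the carbonyl carbon. Compound 1 `O=C(Nc1cc(-c2ccccc2)nn1-c1ccccc1)c1ccc(F)cc1` carries a 4-fluorophenyl there, compound 2 `O=C(Nc1cc(-c2ccccc2)nn1-c1ccccc1)c1cnccn1` a pyrazin-2-yl, and compound 3 `O=C(Nc1cc(-c2ccccc2)nn1-c1ccccc1)c1ccccc1F` a 2-fluorophenyl. In an assay on isolated protein with metabotropic glutamate receptor 5 (Rattus norvegicus) as the target (on this read-out higher numbers stand for an effect only at larger amounts of compound and lower numbers for an effect already at smaller amounts), compound 1 gives 50 nM, compound 2 gives 400 nM, and compound 3 gives 100 nM. The exchanges are felt differently: an 8.0-fold higher number from compound 1 to compound 2 (0.90 log units; beyond the scatter), whereas a 2.0-fold higher number from compound 1 to compound 3 (0.30 log units; within the scatter), and a 4.0-fold lower number from compound 2 to compound 3 (0.60 log units; beyond the scatter). Compound 3 therefore stands second highest of the three numbers, close to compound 1 and well apart from compound 2. Compound 4 `O=C(Nc1cc(-c2ccccc2)nn1-c1ccccc1)c1cccc(F)c1` has not been measured; it differs from compound 3 by 3-fluorophenyl in place of 2-fluorophenyl on a carbonyl carbon. For the measured compounds named here, the one measured step in which one fluorophenyl was exchanged for another, from compound 1 to compound 3, stayed within the scatter, so only a small change is expected here as well, a 1.4-fold lower number from compound 3 to compound 4 (0.15 log units; within the scatter), most likely a slightly lower number. Compound 4 is therefore expected to give 70 nM in this assay, between 30 nM and 160 nM.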

Compound 4, half-maximal effective concentration: 65 nM
Beside the measured number, compound 4's estimate is 1.1-fold (0.03 log units) above it; the measured number falls inside the stated range.
By their numbers in this assay, from the lowest: compounds 1, 4 and 3 (each within the scatter of the next); then compound 2.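

Compound 4 completes the set of 2-fluorophenyl, 3-fluorophenyl and 4-fluorophenyl on the carbonyl carbon, and in this assay the new group gives a 1.5-fold lower number from compound 3 to compound 4 (0.19 log units; within the scatter) and a 1.3-fold higher number from compound 1 to compound 4 (0.11 log units; within the scatter) so these exchanges of one fluorophenyl for another cannot be told apart from ordinary scatter. The exchange for pyrazin-2-yl stands out against this new fluorophenyl as well, with a 6.2-fold lower number from compound 2 to compound 4 (0.79 log units; beyond the scatter) so the gap seen earlier for compound 2 now holds against all three fluorophenyl compounds. Nothing available here explains why the place of the fluorine shows so little effect or why pyrazin-2-yl differs.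

Still open, on these data alone, is whether plain phenyl, 3-chlorophenyl or 3-methoxyphenyl would fall in the same range as the fluorophenyl compounds. Also open, as far as these compounds go, is whether pyridin-2-yl would sit nearer to compound 2 or to that group.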